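Oxazole series: bromo for hydrogen beside the methylsulfanyl group

A few compounds are considered here, and "the series" means these few. Any claim that something is new, unique, unknown or untested is made for them only; others in the source may bear on it.

Measured so far:
compound 1, `COc1cc(-c2ocnc2-c2cc(OC)c(OC)c(OC)c2)ccc1SC` — 430 nM
compound 2, `COc1ccc(-c2c(-c3cc(OC)c(SC)c(OC)c3)ncn2C)cc1O` — 500 nM

Both compounds were tested in an ADME assay on HaCaT cells (Homo sapiens) for cytotoxicity, read by MTT assay, with a stated time of 48 h; a lower number here means a stronger inhibitor, a higher number a weaker inhibitor. Compound 1 gives 430 nM, the lowest of the two numbers; compound 2 gives 500 nM, within the scatter of compound 1, so no order between them can be read. Compound 3, `COc1cc(-c2ncoc2-c2cc(Br)c(SC)c(OC)c2)cc(OC)c1OC`, has not been measured. It differs from compound 1 in one place: bromo in place of hydrogen on an aromatic carbon. For the measured compounds named here, no step between measured compounds covers this change, and the two numbers in hand give no direction for it. The expectation is therefore a step of no clear direction, of a size that may not exceed the scatter, with the estimate for compound 3 leaning slightly toward a higher number given the uncertainty. Compound 3 is estimated at 600 nM, in the range 200 nM to 2000 nM, which corresponds to an expected step of a 1.4-fold higher number from compound 1 to compound 3 (0.14 log units; within the scatter).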

Compound 3, half-maximal inhibitory concentration: 16700 nM
The estimate for compound 3 lay 28-fold (1.44 log units) below the measured number; the whole stated range lies below it.
By their numbers in this assay, from the lowest: compounds 1 and 2 (each within the scatter of the next); then compound 3.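

In this assay, this position does not tolerate every change: bromo in place of hydrogen on an aromatic carbon, ortho to a methylsulfanyl group and meta to a methoxy group, gives a 39-fold higher number from compound 1 to compound 3 (1.59 log units; beyond the scatter). The earlier compounds shown here carry hydrogen at this position, so they gave no reading of what a substituent does there. A single entering heavy atom is now enough to set compound 3 clearly apart from compound 1, so this position counts as sensitive in this series.

From the compounds shown here alone, with one step, it remains open whether the rise belongs to bromo alone or would follow any group placed here, such as a fluorine atom, a chlorine atom or an amine. Nothing in hand accounts for the size of this step.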